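Replacing the Piperidine Group on the Core of Compound 1

A few compounds are considered here, and "the series" means these few. Any claim that something is new, unique, unknown or untested is made for them only; others in the source may bear on it.

Compound 1 `CCC1CCN(c2nc(C(C)(C)C)ccc2CNC(=O)C(C)c2ccc(NS(C)(=O)=O)c(F)c2)CC1`: 0.1 nM
Compound 2 `CC(C(=O)NCc1ccc(C(C)(C)C)nc1OCc1ccc(F)cc1)c1ccc(NS(C)(=O)=O)c(F)c1`: 0.8 nM
Compound 3 `CCCCCCSc1nc(C(C)(C)C)ccc1CNC(=O)C(C)c1ccc(NS(C)(=O)=O)c(F)c1`: 1.5 nM

In an assay on cells for antagonist activity at transient receptor potential cation channel subfamily V member 1 (Homo sapiens), read by FLIPR and calcium flux, with a stated time of 6 min (on this read-out higher numbers stand for weaker inhibition and lower numbers for stronger inhibition), compound 1 holds the lowest number of the three, and both steps away from it are beyond the scatter. Compound 4 `CC(C(=O)NCc1ccc(C(C)(C)C)nc1SCCCN1CCCC1)c1ccc(NS(C)(=O)=O)c(F)c1` is made from compound 1 by one change: (3-(pyrrolidin-1-yl)propyl)sulfanyl in place of 4-ethylpiperidin-1-yl on an aromatic carbon. Two measured steps remove the same group: an 8.0-fold higher number from compound 1 to compound 2 (0.90 log units; beyond the scatter) and a 15-fold higher number from compound 1 to compound 3 (1.18 log units; beyond the scatter), both weakening inhibition. Between the two replacements, a 1.9-fold higher number from compound 2 to compound 3 (0.27 log units; within the scatter) lies within the scatter, so the new group's identity mattered little. Since the entering group, like hexylsulfanyl, attaches through sulfur, a comparable loss is expected, about a 15-fold higher number from compound 1 to compound 4 (1.18 log units; beyond the scatter). Compound 4 is therefore estimated at 1.5 nM, within 0.4 nM to 6 nM.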

Compound 4, inhibition constant: 17.1 nM
Estimate against measurement, compound 4: 11-fold (1.06 log units) below, and the stated range ends below it.
By their numbers in this assay, from the lowest: compound 1; then compounds 2 and 3 (each within the scatter of the next); then compound 4.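

Pyrrolidin-1-yl in place of propyl at the chain end gives an 11-fold higher number from compound 3 to compound 4 (1.06 log units; beyond the scatter) with the sulfur link kept, so the sulfur link alone does not set the loss at this position. The full replacement of 4-ethylpiperidin-1-yl costs a 170-fold higher number from compound 1 to compound 4 (2.23 log units; beyond the scatter) in this assay, and a 21-fold higher number from compound 2 to compound 4 (1.33 log units; beyond the scatter) shows that the identity of the entering group does matter here. Nothing measured on hand accounts for this loss.
Still open, as far as these compounds go, is whether a shorter chain carrying the same pyrrolidine would lose as much, or whether a dimethylamino group at the chain end would.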